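Dithiocarbamate benzamides: pyrimidinyl in place of pyridinylmethyl

The source may report more compounds than this note shows. Statements on the series, on what has been measured and on what is new or still open speak of the compounds shown alone.

Measured so far in a functional assay on A-375 cells (Homo sapiens) for antiproliferative activity, read by CCK-8 assay, with a stated time of 72 h, tested at 8 uM; a lower number here means a weaker effect, a higher number a stronger effect of the compound at the concentration tested:
compound 1 `Nc1ccccc1NC(=O)c1ccc(CSC(=S)N2CCN(Cc3ccccn3)CC2)cc1` gives 82.4%
compound 2 `Nc1ccccc1NC(=O)c1ccc(CSC(=S)N2CCN(C(c3ccccc3)c3ccccc3)CC2)cc1` gives 8.4%
compound 3 `Nc1ccccc1NC(=O)c1ccc(CSC(=S)N2CCCc3ccccc32)cc1` gives 81.5%

Compound 1 has the highest number of the three in this assay, but its nearest neighbour, compound 3, lies within the scatter of it, so the two cannot be ordered. Compound 2 sits far below both, beyond the scatter. The three compounds share one core and differ only in the amine part of the dithiocarbamate, so the spread seen so far lies entirely in that part.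

Compound 4 `Nc1ccccc1NC(=O)c1ccc(CSC(=S)N2CCN(c3ncccn3)CC2)cc1` is not yet measured. Against compound 1 the change is pyrimidin-2-yl in place of (pyridin-2-yl)methyl on an amine nitrogen in a ring. Among the measured compounds shown here, no step between two measured compounds matches this change, so its size is not known from the series. What the series shows is that a single aromatic ring on the ring nitrogen of compound 1 keeps a high number, while the two rings of compound 2 give a low one. Compound 4 keeps a single ring, so a step of modest size, downward or none beyond the scatter, is expected in this assay, as a number 12.4 percentage points lower from compound 1 to compound 4 (beyond the scatter). Compound 4 is estimated at 70%, with a range from 40% to 88%.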

Compound 4, a percentage reported as inhibition, at one concentration (the size of the read-out at that concentration, not a potency): 67.9%
Estimate against measurement, compound 4: 2.1 percentage points above; the range from low to high includes it.
By their numbers in this assay, from the lowest: compound 2; then compound 4; then compounds 3 and 1 (each within the scatter of the next).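

In this assay, among the compounds shown here, the step at this ring nitrogen is a number 14.5 percentage points lower from compound 1 to compound 4 (beyond the scatter), the first step that can be read at this position, and it is modest in size. Compound 4 gives 67.9%, so in this one pair a single aromatic ring keeps a sizeable number when the methyl link is gone and the ring carries two hetero atoms in place of one, but the number does not stay within the scatter of compound 1. The step combines those two changes, so this pair cannot assign it to either one, and nothing measured here bears on why the number falls.

Still open, from the compounds shown here alone, is whether pyridin-2-yl on the ring nitrogen or (pyrimidin-2-yl)methyl would separate the effect of the methyl link from that of the second ring nitrogen. The compounds shown also leave open how a benzyl group or a plain phenyl ring, neither with a hetero atom, would read at this position in this assay, and whether a small alkyl group such as methyl would hold the number.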